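This account rests on a few compounds, and the source may have more. Where it says the series, first, only, none or still open, it means among the compounds named here.

Working notes on the series. Compound 1 `CCOC(=O)CCCCCOc1cccc(CNC(C)C)c1` and compound 2 `CCOC(=O)CCCCCOc1ccc(CNC(C)C)cc1` share the same atoms; the difference between their cores is not broken down here. Compound 3 `CCCNCc1cccc(OCCCCCC(=O)OCC)c1` comes from compound 1 by propyl in place of isopropyl on an amine nitrogen, and compound 4 `CCCNCc1ccc(OCCCCCC(=O)OCC)cc1` comes from compound 2 by propyl in place of isopropyl on an amine nitrogen, the same change at the same place. In an ADME assay on HEK293 cells (Homo sapiens) for cytotoxicity, read by CellTiter-Glo and resazurin assay, with a stated time of 72 h (a higher number here means that more compound is needed for the effect, a lower number that less compound is needed), compound 1 gives > 26000 nM, a limit of the assay rather than a number. Compound 2 gives > 26000 nM in this assay, again a limit. Compound 3 gives > 26000 nM in this assay, also a limit. The step that the two limits leave unreadable from compound 1 to compound 3 thus cannot be sized, because of the limit of > 26000 nM in this assay, at which 3 of the 3 values shown sit. For compound 4 the matching step is expected to be a step that the limit leaves unreadable from compound 2 to compound 4. That rests on compound 3 having reached only a limit, > 26000 nM, in this assay. Compound 4 is estimated at 40000 nM, between 15000 nM and 120000 nM.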

Compound 4, half-maximal effective concentration: > 26000 nM
Compound 4 ended at the assay's limit; the forecaster's own chance of this, stated with the estimate: 85%; the middle value does not contradict the limit.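

The change from compound 2 to compound 4 gives no readable step, because both compounds stand at a limit rather than a number: the limit of > 26000 nM in this assay, at which 4 of the 4 values shown sit.

The compounds shown leave open whether propyl and isopropyl on the amine nitrogen differ at all in this assay.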